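Swapping a dimethylamino for a pyrrolidinyl on a coumarin ketone

The source may report more compounds than this note shows. Statements on the series, on what has been measured and on what is new or still open speak of the compounds shown alone.

Four coumarin ketones bearing a basic amine on a short side chain were compared in an assay on cells for inhibition of Amine oxidase [flavin-containing] B (Homo sapiens), read by fluorescence, spectrophotometry and Amplex Red, with stated times of 60 min and 30 min; on this read-out higher numbers stand for weaker inhibition and lower numbers for stronger inhibition. Compound 1 `COc1ccc2cc(C(=O)CCN(C)C)c(=O)oc2c1` carries a dimethylamino group and in this assay compound 1 gives 21100 nM. Compound 2 `COc1ccc2cc(C(=O)CCN3CCCC3)c(=O)oc2c1` differs from it by pyrrolidin-1-yl in place of dimethylamino on a saturated chain carbon, two bonds along the chain from a carbonyl carbon, and in this assay compound 2 gives 18100 nM. The measured step is a 1.2-fold lower number from compound 1 to compound 2 (0.07 log units; within the scatter), so the two values cannot be told apart.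

Compound 3 `CN(C)CCC(=O)c1cc2cc(Br)c(O)c(Br)c2oc1=O` has a different core, one with a hydroxy group and two bromine atoms; how its core differs from that of compound 1 is not broken down here. In this assay compound 3 gives only a limit of the assay, > 200000 nM. This is the limit of > 200000 nM in this assay, at which 1 of the 3 values shown sits.

Compound 4 `O=C(CCN1CCCC1)c1cc2cc(Br)c(O)c(Br)c2oc1=O` has not yet been measured. It differs from compound 3 by pyrrolidin-1-yl in place of dimethylamino on a saturated chain carbon, two bonds along the chain from a carbonyl carbon, the same change seen between compound 1 and compound 2, made at the same place on the chain.

The step from compound 3 to compound 4 is expected to be a step that the limit leaves unreadable from compound 3 to compound 4, since the measured step of a 1.2-fold lower number from compound 1 to compound 2 (0.07 log units; within the scatter) lay within the scatter. Compound 4 is therefore expected to give 250000 nM, with a likely spread from 100000 nM to 600000 nM, and most probably only a limit again.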

Compound 4, half-maximal inhibitory concentration: > 200000 nM
Compound 4: a limit, no number; the forecaster's own chance of this, stated with the estimate: 75%; the middle value lies beyond the limit too.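

Within the data shown here, compound 3 and compound 4 both end at a limit of the assay rather than a number, so no step between them can be read: the limit of > 200000 nM in this assay, at which 2 of the 4 values shown sit. The compounds shown leave open whether pyrrolidin-1-yl in place of dimethylamino makes any difference in this assay on the core with the hydroxy group and two bromine atoms.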